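The compounds below may be only part of what the source reports. "The series", "measured", "known", "first", "only" and "open" are said of these compounds alone.

Compound 2 `Cc1cc(Nc2cc(-c3ccccc3)[nH]n2)n2nc(SCc3cccc(Br)c3)nc2n1`: 5140 nM
Compound 3 `Cc1cc(Nc2cc(C(C)(C)C)[nH]n2)n2nc(SCc3ccc(Br)cc3)nc2n1`: 7290 nM
Compound 1 `Cc1cc(Nc2ccn(Cc3ccccc3)n2)n2nc(SCc3ccc(Br)cc3)nc2n1`: 15800 nM

All three were tested in a functional assay on MCF7 cells (Homo sapiens) for inhibition, read by MTT assay, with a stated time of 72 h; a lower number here means a stronger inhibitor, a higher number a weaker inhibitor. Compound 2 gives the lowest number of the three, but its gap to compound 3 lies within the scatter, so no order between those two can be claimed; compound 1 stands beyond the scatter with a higher number. Compound 4 `CCCSc1nc2nc(C)cc(Nc3cc(-c4ccccc4)[nH]n3)n2n1` has not yet been measured. It differs from compound 2 in one place: ethyl in place of 3-bromophenyl on a saturated chain carbon bound to a sulfur. Among the measured compounds shown here, no pair of measured compounds shows a step of this kind, so its size is uncertain. Compound 4 is expected to be a weaker inhibitor than compound 2, by a step of a 3.1-fold higher number from compound 2 to compound 4 (0.49 log units; beyond the scatter), beyond the scatter. The estimate for compound 4 in this assay is 16000 nM, ranging from 5000 nM to 50000 nM.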

Compound 4, half-maximal inhibitory concentration: > 50000 nM
Compound 4 ended at the assay's limit; the forecaster's own chance of this, stated with the estimate: 10%; middle value at least 3.1-fold (0.49 log units) away from the limit.
By their numbers in this assay, from the lowest: compounds 2 and 3 (each within the scatter of the next); then compound 1. At a limit, above all of these: compound 4.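

In this assay, among the compounds shown here, the only step at this position is large: ethyl in place of 3-bromophenyl on a saturated chain carbon bound to a sulfur gives an at least 9.7-fold higher number from compound 2 to compound 4 (0.98 log units; beyond the scatter). Compound 4 gives > 50000 nM, which is a limit of the assay and not a number. For this pair, then, cutting 3-bromobenzyl back to propyl costs clear inhibition, and the full size of that loss cannot be read: the limit of > 50000 nM in this assay, at which 1 of the 4 values shown sits.

The step removes the ring and the bromine together, and the compounds shown do not separate them. From the compounds shown here alone, how a plain benzyl group or a hexyl chain on the sulfur would read stays open.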